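The source may report more compounds than this note shows. Statements on the series, on what has been measured and on what is new or still open speak of the compounds shown alone.

Measured so far in an ADME assay for permeability, using PAMPA, at pH 7.4; on this read-out higher numbers stand for higher permeability and lower numbers for lower permeability 
- compound 1 (`CSc1ccc(NC(=O)Nc2cc(C)nc3ccccc23)cc1`) gives 473 10^-6 cm/s 
- compound 2 (`Cc1cc(NC(=O)Nc2ccc(O)cc2)c2ccccc2n1`) gives 3 10^-6 cm/s 

Among the measured compounds shown here, compound 2 holds the lower of these two numbers, and compound 1 is its only point of comparison. The change to compound 3 (`Cc1cc(NC(=O)Nc2ccc(OC(F)(F)F)cc2)c2ccccc2n1`) is trifluoromethyl in place of hydrogen on an oxygen on an aromatic ring and amounts to trifluoromethyl in place of hydrogen on an oxygen on an aromatic ring, so hydroxy becomes trifluoromethoxy. For the measured compounds named here, one measured step bears on this: hydroxy in place of methylsulfanyl on an aromatic carbon gave a 160-fold lower number from compound 1 to compound 2 (2.20 log units; beyond the scatter) as a large drop. Compound 3 has no hydroxy, as compound 1 has none, so that step read backwards is the guide, although trifluoromethoxy is not methylsulfanyl and a single step is thin evidence. In this assay the expected result is a 130-fold higher number from compound 2 to compound 3 (2.12 log units; beyond the scatter) and so a large rise. Compound 3 is estimated at 400 10^-6 cm/s with 120 10^-6 cm/s and 1000 10^-6 cm/s as the expected ends of its range.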

Compound 3, apparent permeability: 531 10^-6 cm/s
Compound 3: middle estimate off by 1.3-fold (0.12 log units), on the low side; the range from low to high includes it.
By their numbers in this assay, from the lowest: compound 2; then compounds 1 and 3 (each within the scatter of the next).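

At this position on the aromatic ring, putting trifluoromethyl on the oxygen of the hydroxy group gives, in this assay, a 180-fold higher number from compound 2 to compound 3 (2.25 log units; beyond the scatter). Putting trifluoromethoxy in place of methylsulfanyl gives a 1.1-fold higher number from compound 1 to compound 3 (0.05 log units; within the scatter), so these two groups cannot be told apart on this read-out. Of the three groups shown, hydroxy alone now stands low, whereas the earlier pair could not say whether the large gap came from hydroxy or from something particular to methylsulfanyl.

Nothing measured here explains why hydroxy stands apart. Also open, as far as these compounds go, is whether an amine, a carboxylic acid or a plain methoxy at this place would stay level with the two high numbers or fall towards the hydroxy compound.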